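Swapping furan-2-yl for phenyl on an inactive nucleoside

The source may report more compounds than this note shows. Statements on the series, on what has been measured and on what is new or still open speak of the compounds shown alone.

Measured in a functional assay on CEM-DNR-bulk cells (Homo sapiens), read by MTT assay, with a stated time of 72 h (a higher number here means a weaker inhibitor, a lower number a stronger inhibitor), with a half-maximal inhibitory concentration as the read-out:
- Compound 1 `CSc1ncnc2c1c(-c1ccoc1)cn2[C@@H]1O[C@H](CO)[C@@H](O)[C@H]1O`: > 20000 nM
- Compound 2 `CSc1ncnc2c1c(-c1ccsc1)cn2[C@@H]1O[C@H](CO)[C@@H](O)[C@H]1O`: > 20000 nM
- Compound 3 `CNc1ncnc2c1c(-c1ccco1)cn2[C@@H]1O[C@H](CO)[C@@H](O)[C@H]1O`: > 20000 nM

Each of these entries is a limit of the assay and not a number. In this assay compound 3 gives > 20000 nM, which is such a limit. It shares that position with the other two compounds: the limit of > 20000 nM in this assay, at which 3 of the 3 values shown sit.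

Compound 4 `CNc1ncnc2c1c(-c1ccccc1)cn2[C@@H]1O[C@H](CO)[C@@H](O)[C@H]1O` is the next to be read, and it carries phenyl in place of furan-2-yl on an aromatic carbon. The change sits on the five-membered aromatic ring with 1 nitrogen, part of the fused system of two rings.

Among the compounds with values here, only one measured step comes close to this change, an exchange of one aromatic ring for another: a step that the two limits leave unreadable from compound 1 to compound 2. Its two ends are limits, so it offers no size to carry over. The expectation therefore rests on compound 3 with > 20000 nM, and on the absence of any measured number in this set. In this assay the estimated change is a number no higher from compound 3 to compound 4 (the limit leaves the size open), and no shift in either direction is expected beyond the scatter. Compound 4 is estimated at 20000 nM, with an expected range from 8000 nM to 40000 nM.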

Compound 4, half-maximal inhibitory concentration: > 20000 nM
Compound 4: a limit, no number; the forecaster's own chance of this, stated with the estimate: 85%; the middle value lies on the limit itself.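

In this assay compound 4 gives > 20000 nM, a limit of the assay and not a number. Compound 3 also stands at a limit, and no step can be read between compound 3 and compound 4. The compounds shown leave open what effect, if any, exchanging one aromatic ring for another has on the shared core: the limit of > 20000 nM in this assay, at which 4 of the 4 values shown sit.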